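The source may report more compounds than this note shows. Statements on the series, on what has been measured and on what is new or still open speak of the compounds shown alone.

Measured compounds:

Compound 1, `CC/C(=C(/c1ccc(N)cc1)c1ccc(OCCN)cc1)c1ccccc1`, gives 53.1 nM in an assay on isolated protein for inhibition of Aromatase (Homo sapiens), read by fluorescence, with a stated time of 30 min; on this read-out lower numbers stand for stronger inhibition and higher numbers for weaker inhibition.
Compound 2, `CC/C(=C(/c1ccc(O)cc1)c1ccc(CCCN)cc1)c1ccccc1`, gives 7340 nM in this assay.
Compound 3, `CC/C(=C(/c1ccc(N)cc1)c1ccc(OCCN)cc1)c1ccc(O)cc1`, gives 48.1 nM in this assay.

Three compounds share a closely related skeleton built around a central double bond carrying three aromatic rings. Compound 1 and compound 3 differ in a single place, (hydroxy in place of hydrogen on an aromatic carbon). That change produced a 1.1-fold lower number from compound 1 to compound 3 (0.04 log units; within the scatter), so the two compounds cannot be told apart on this read-out.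

Compound 2 has a different core from compound 1; the difference between the two cores is not broken down here. What the values show is that compound 2 stands far higher than both compound 1 and compound 3 in this assay.

Compound 4, `CC/C(=C(/c1ccc(O)cc1)c1ccc(CCCN)cc1)c1ccc(O)cc1`, has not yet been measured. It is related to compound 2 by hydroxy in place of hydrogen on an aromatic carbon, which is the same change that led from compound 1 to compound 3, made at the same kind of place. Because that change gave a 1.1-fold lower number from compound 1 to compound 3 (0.04 log units; within the scatter), a step of similar size is expected from compound 2 to compound 4, namely a 1.1-fold lower number from compound 2 to compound 4 (0.05 log units; within the scatter), in this assay. The value of compound 4 is therefore estimated to lie close to that of compound 2, at about 6600 nM, with a plausible range from 2500 nM to 18000 nM.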

Compound 4, half-maximal inhibitory concentration: 491 nM
Estimate against measurement, compound 4: 13-fold (1.13 log units) above; measured number below the stated range.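

In this assay, putting a hydroxy group in place of hydrogen, which turns phenyl into 4-hydroxyphenyl, gave a 15-fold lower number from compound 2 to compound 4 (1.17 log units; beyond the scatter), a large step on the core of compound 2. Set beside the earlier step, the same change did not keep its size from one core to the other: the same change on two cores in this assay, a 1.1-fold lower number (0.04 log units; within the scatter) from compound 1 to compound 3 and a 15-fold lower number (1.17 log units; beyond the scatter) from compound 2 to compound 4, 14-fold (1.13 log units) apart, beyond the scatter of two such steps. This shows that the size of a step measured on one core cannot simply be copied to another core in this series, but it does not show which feature of the cores is responsible, as compound 1 and compound 2 differ in more than one place, and two pairs of compounds give no rule for any further core.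

The compounds shown leave open which of the differences between the two cores goes with the large step, a question that cores carrying only one of those differences could help to answer. They also leave open whether a methoxy group or a fluorine atom in the same place would give a large step on the core of compound 2 or a step within the scatter on the core of compound 1.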